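This account rests on a few compounds, and the source may have more. Where it says the series, first, only, none or still open, it means among the compounds named here.

Measured so far:
compound 1 `O=C(Nc1nc(-c2ccncc2)c(CN2CCCC2)s1)c1ccncc1` gives 47.6%
compound 2 `CN1CCN(c2sc(NC(=O)c3ccncc3)nc2-c2ccncc2)CC1` gives 34.3%

Both numbers come from an assay on isolated protein for inhibition of Rho-associated protein kinase 2 (Homo sapiens), read by ELISA, with a stated time of 30 min, tested at 10 uM, in the presence of a further agent that is not named here; on this read-out higher numbers stand for more inhibition at the one concentration tested (going by the name of the read-out) and lower numbers for less inhibition. For the measured compounds named here, compound 2 stands at the lower of the two values: the only other measured compound, compound 1, sits higher by a margin described as beyond the scatter, a number 13.3 percentage points lower from compound 1 to compound 2 (beyond the scatter).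

The next compound, compound 3 `CC(C)N(C)c1sc(NC(=O)c2ccncc2)nc1-c1ccncc1`, has not yet been measured in this assay. It differs from compound 2 in one place: isopropyl(methyl)amino in place of 4-methylpiperazin-1-yl on an aromatic carbon. The group that enters is smaller than the one that leaves and has no ring, but it is attached to the same aromatic carbon of the shared core.

Going by the values given here, only one measured step exists to lean on, and it swapped a different pair of groups at that position, a number 13.3 percentage points lower from compound 1 to compound 2 (beyond the scatter), so it offers only a loose guide to whether the number in this assay comes out higher, lower or level after a change at this part of the molecule. Among the compounds with values here, no measured pair shows the present swap itself. On that basis, compound 3 is expected to land close to compound 2, with a step of about a number 2.3 percentage points lower from compound 2 to compound 3 (within the scatter) that is not confidently beyond the scatter in either direction. The estimate for compound 3 in this assay is 32%, with a range from 12% to 52%.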

Compound 3, a percentage reported as inhibition, at one concentration (the size of the read-out at that concentration, not a potency): 32.1%
For compound 3 the middle estimate is 0.1 percentage points below the measured one, within the range that was stated.
By their numbers in this assay, from the lowest: compounds 3 and 2 (each within the scatter of the next); then compound 1.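

In this assay, replacing 4-methylpiperazin-1-yl with isopropyl(methyl)amino gives a number 2.2 percentage points lower from compound 2 to compound 3 (within the scatter), so at this aromatic carbon, next to the ring sulfur, the number does not separate a group with a six-membered ring from an open group with no ring. The step of a number 15.5 percentage points lower from compound 1 to compound 3 (beyond the scatter) is similar in direction to the earlier step from compound 1, and it shows that two different groups joined to the shared core through nitrogen both give numbers beyond the scatter from that of compound 1, whose (pyrrolidin-1-yl)methyl group is joined through a methylene link. Among these three compounds, nothing available explains why the numbers fall as they do.

The compounds shown leave open whether the higher number of compound 1 goes with the methylene link or with the pyrrolidine ring, since each of its steps changes both at once. A (4-methylpiperazin-1-yl)methyl group or a pyrrolidin-1-yl group at this same carbon would bear directly on that question.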